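Replacing the benzylamine of compound 1 with an aryl thioether

The compounds below may be only part of what the source reports. "The series", "measured", "known", "first", "only" and "open" are said of these compounds alone.

Of the compounds shown here, two built on a shared core have been measured in a functional assay on MDA-MB-435 cells (Homo sapiens) for inhibition, read by sulforhodamine B assay, with a stated time of 48 h; on this read-out higher numbers stand for weaker inhibition of growth and lower numbers for stronger inhibition of growth. Compound 1 `Nc1cc(N)c2nc(-c3ccccc3)c(NCc3ccc(F)cc3)nc2c1` gives 3720 nM, the lowest of the two numbers. For the measured compounds named here, compound 2 `COc1ccc(CNc2nc3cc(N)cc(N)c3nc2-c2ccccc2)cc1` gives 21900 nM, and the only step between measured compounds is a 5.9-fold higher number from compound 1 to compound 2 (0.77 log units; beyond the scatter), which changes a single substituent on the pendant ring. Compound 3 `Nc1cc(N)c2nc(-c3ccccc3)c(Sc3ccc(Cl)c(Cl)c3)nc2c1` differs from compound 1 in a larger way: (3,4-dichlorophenyl)sulfanyl in place of (4-fluorobenzyl)amino on an aromatic carbon. Going by the values given here, no measured step touches this change, and the one step available concerns a different part of that side group, so its size is only a rough guide. Given that the single substituent exchange from compound 1 to compound 2 already moved this assay beyond the scatter, compound 3 is expected to show a step of a 3.2-fold higher number from compound 1 to compound 3 (0.51 log units; beyond the scatter) toward a higher number. Compound 3 is therefore estimated at 12000 nM, within a range of 2500 nM to 60000 nM.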

Compound 3, concentration for total growth inhibition: 60300 nM
Compound 3: middle estimate off by 5.0-fold (0.70 log units), on the low side; the measured number lies above the stated range.
By their numbers in this assay, from the lowest: compound 1; then compound 2; then compound 3.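

In this assay the side group at this position was replaced as a whole, and this gave a 16-fold higher number from compound 1 to compound 3 (1.21 log units; beyond the scatter), a large rise in the number. The earlier step touched only a substituent on the pendant ring, whereas this one shows that growth inhibition also responds to a change of the whole group, even though the leaving and entering groups both count 9 heavy atoms and the entering group has 0 hydrogen-bond donors against 1. Nothing available bears on why the number rises. Going by these compounds, the change alters the link to the core and the ring substituents at once, so their separate shares remain open. A (4-fluorophenyl)sulfanyl or a (3,4-dichlorobenzyl)amino group at this position would be needed to tell them apart, and the effect of an ether oxygen as the link is also unknown.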